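Compound 3 to compound 4: a weak starting point

The source may hold more compounds than are shown below. What is called first, only, known or untested is meant among the compounds shown, and "the series" means these compounds.

Results in a functional assay on SGC-7901 cells (Homo sapiens) for antiproliferative activity, read by sulforhodamine B assay, with a stated time of 72 h (a lower number here means a stronger inhibitor, a higher number a weaker inhibitor), so far:
Compound 1 (`COc1ccc(C)cc1NC(=S)N/N=C/c1ccc2ccccc2n1`): > 100000 nM (a limit of the assay)
Compound 2 (`NC(=S)N/N=C/c1nc2ccccc2s1`): > 100000 nM (a limit of the assay)
Compound 3 (`Cc1ccc(NC(=S)N/N=C/c2ccc3ccccc3n2)cc1`): 92900 nM

Compound 3 is the only one of the three with a true number, at 92900 nM in this assay as its reading. The rest of the picture is set by the limit of > 100000 nM in this assay, at which 2 of the 3 values shown sit, and offers no second number for comparison. The next compound is compound 4 (`S=C(N/N=C/c1ccc2ccccc2n1)Nc1cccc(Cl)c1`), in which 3-chlorophenyl replaces 4-methylphenyl on an amide-type nitrogen (3-chlorophenyl in place of 4-methylphenyl on an amide-type nitrogen). Within the data shown here, no measured pair isolates a single change, so the data give no direct size for this exchange. Compound 3, with 92900 nM as its starting point, leaves little room for a weaker number. A modest gain in inhibition is therefore expected, and the estimated change, a 1.9-fold lower number from compound 3 to compound 4 (0.27 log units; within the scatter) as a central figure, may not clear the usual scatter by much. Compound 4 is expected at about 50000 nM with an estimated range (10000 nM to 100000 nM).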

Compound 4, half-maximal inhibitory concentration: 61300 nM
The estimate for compound 4 lay 1.2-fold (0.09 log units) below the measured number, and the stated range covers the measured number.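

In this assay, among these compounds, the exchange of 4-methylphenyl for 3-chlorophenyl on an amide-type nitrogen gives the first step that can be read, a 1.5-fold lower number from compound 3 to compound 4 (0.18 log units; within the scatter), and with that step inside the scatter, the two groups cannot be told apart at this position. The data therefore show that this particular exchange, which keeps the same count of heavy atoms, leaves the reading essentially where it was. Among the compounds shown here, compound 1 and compound 2 remain at a limit of the assay and supply no further measured step: (the limit of > 100000 nM in this assay, at which 2 of the 4 values shown sit).

The compounds shown leave open whether a different kind of group on this nitrogen, such as a carboxylic acid, a primary amine or a longer alkyl chain, would move the number beyond the scatter. They also leave open whether changes elsewhere on the shared core would matter more than this one.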